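The source may report more compounds than this note shows. Statements on the series, on what has been measured and on what is new or still open speak of the compounds shown alone.

Measured compounds in an ADME assay on microsomes from liver (Mus musculus) for metabolic stability, read by LC-MS, with NADPH named in the record, with a stated time of 60 min, tested at 1 uM, in the absence of a further agent; on this read-out lower numbers stand for a less stable compound and higher numbers for a more stable compound:

- compound 1, `COc1ccc(-c2c(C)sc3c(N4CC[C@@H](NC(C)=O)C4)nc(C)nc23)cc1OC`: compound 1 gives > 95%, a limit of the assay.
- compound 2, `CC(=O)N[C@@H]1CCN(c2cc(C)nn3c(-c4ccc5cc[nH]c5c4)c(C)nc23)C1`: compound 2 gives > 95%, a limit of the assay.
- compound 3, `COc1ccc(-c2c(C)nc3c(N4CC[C@@H](NC(=O)COc5ccccc5)C4)cc(C)nn23)cc1OC`: compound 3 gives > 95%, a limit of the assay.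

Compound 3 stands at the upper limit of the read-out, and every other value shown sits there too, so no ordering among the measured compounds is possible (the limit of > 95% in this assay, at which 3 of the 3 values shown sit). Among the compounds with values here, no pair of measured compounds differs in only one place, so no measured step is available for comparison.

The next compound is compound 4, `COc1ccc(-c2c(C)nc3c(N4CC[C@@H](NS(=O)(=O)c5ccc(C#N)cc5)C4)cc(C)nn23)cc1OC`. Against compound 3 the difference is (4-cyanophenyl)sulfonyl in place of (phenoxymethyl)carbonyl on an amine nitrogen. All three measured compounds reach the limit in this assay regardless of what sits on the amine nitrogen, so the change is expected to leave the read-out within the scatter, with no step beyond it in either direction. The expected step of a number at least 3 percentage points lower from compound 3 to compound 4 (that floor lies within the scatter) is therefore essentially flat. For compound 4 the estimated value is 92%, with a range from 72% to 99%, and a high chance that only the limit is reported again.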

Compound 4, percent of the compound remaining: > 95%
Compound 4: a limit, no number; the forecaster's own chance of this, stated with the estimate: 60%; middle value at least 3 percentage points from the limit.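

In this assay compound 4 gives > 95% as a limit of the assay. No step can be read from compound 3 to compound 4, because both values are limits: the limit of > 95% in this assay, at which 4 of the 4 values shown sit.

The compounds shown leave open how far their stability in this assay differs, and whether any group on the amine nitrogen brings a value off the limit.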